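A few compounds are considered here, and "the series" means these few. Any claim that something is new, unique, unknown or untested is made for them only; others in the source may bear on it.

In an ADME assay on S9 fraction from liver (Rattus norvegicus) for metabolic stability, with a stated time of 1 h (on this read-out lower numbers stand for a less stable compound and higher numbers for a more stable compound), compound 3 `N#Cc1cnc(NCc2cnccc2C(F)(F)F)cc1NC[C@H]1CC[C@H](O)CC1` stands lowest of the three measured compounds at 6%, against compound 1 `N#Cc1cnc(NCc2cnccc2C(F)(F)F)cc1NC[C@H]1C[C@@H](O)C1` at 44% and compound 2 `N#Cc1cnc(NCc2cnccc2C(F)(F)F)cc1NC[C@H]1C[C@H](O)C1` at 61%. The next structure is compound 4 `CNC(=O)[C@H]1CC[C@@H](Nc2cc(NCc3cnccc3C(F)(F)F)ncc2C#N)CC1`, and the change is 4-(methylcarbamoyl)cyclohexyl in place of (4-hydroxycyclohexyl)methyl on a nitrogen on an aromatic ring.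

Two measured steps end at compound 3, and both exchange 3-hydroxycyclobutyl for 4-hydroxycyclohexyl: a number 38 percentage points lower from compound 1 to compound 3 (beyond the scatter) and a number 55 percentage points lower from compound 2 to compound 3 (beyond the scatter). Both are large, so changes to this part of the structure have moved this assay strongly in this small set. The remaining step, a number 17 percentage points higher from compound 1 to compound 2 (beyond the scatter), is modest and comes with the fact that compounds 1 and 2 differ only in the configuration as drawn. It shows that even a change in configuration alone can register on this read-out.

None of these steps exchanges a hydroxyl-bearing group for 4-(methylcarbamoyl)cyclohexyl, so the transfer to compound 4 is loose and the range must stay wide. Compound 3 at 6% leaves little room for a fall, so an upward move of modest size is expected in this assay. The expected change is a number 14 percentage points higher from compound 3 to compound 4 (beyond the scatter). For compound 4 the estimated value is 20%, with an expected range from 5% to 50%.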

Compound 4, percent of the compound remaining: 53%
Beside the measured number, compound 4's estimate is 33 percentage points below it, and the stated range ends below it.
By their numbers in this assay, from the lowest: compound 3; then compounds 1, 4 and 2 (each within the scatter of the next, the first and the last beyond it).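

In this assay, a six-membered carbon ring at this position does not by itself mean a low number, as the exchange of (4-hydroxycyclohexyl)methyl for 4-(methylcarbamoyl)cyclohexyl on a nitrogen on an aromatic ring gives a number 47 percentage points higher from compound 3 to compound 4 (beyond the scatter). This exchange brings the series back to the range of the two cyclobutyl compounds, with a number 8 percentage points lower from compound 2 to compound 4 (within the scatter) and a number 9 percentage points higher from compound 1 to compound 4 (within the scatter), so compound 4 cannot be ordered against either of them. Those two stand apart, with a number 17 percentage points higher from compound 1 to compound 2 (beyond the scatter), although compound 4 lies within the scatter of both, and one structural fact separates them: the fact that compounds 1 and 2 differ only in the configuration as drawn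

The step from compound 3 to compound 4 changes two things at once, the attachment of the ring directly to the nitrogen and the exchange of hydroxyl for methylcarbamoyl, and the compounds shown do not tell which of these carries the gain. Also open, as far as these compounds go, is how a 4-hydroxycyclohexyl group set directly on that nitrogen, or a carboxylic acid or an amine in place of the methylcarbamoyl, would read in this assay.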